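A few compounds are considered here, and "the series" means these few. Any claim that something is new, unique, unknown or untested is made for them only; others in the source may bear on it.

In a physicochemical assay for lipophilicity, at pH 7.4 (a lower number here means a more polar compound, a higher number a more lipophilic compound), compound 1 `Cc1cc(C)c(CN2CCc3ccc(OC(C)C)cc3C2=O)c(=O)[nH]1` stands at 2.5 and is the higher of the two measured compounds. Compound 2 `Cc1cc(C)c(CNC(=O)c2cccc(OC(C)C)c2Cl)c(=O)[nH]1` gives 2 and lies lower by more than the usual scatter. Compound 3 `Cc1cc(C)c(CN2CCc3ccc(OC(C)C)c(Cl)c3C2=O)c(=O)[nH]1` carries one change from compound 1 chloro in place of hydrogen on an aromatic carbon in the form of chloro in place of hydrogen on an aromatic carbon, ortho to an isopropoxy group. Among the compounds with values here, no measured pair shows this change alone. The expected rise in this assay lies beyond the scatter, an estimated a number 0.50 log units higher from compound 1 to compound 3 (beyond the scatter) in size. For compound 3 the expected value is 3 with an estimated range of 2.6 to 3.4 for the coming measurement.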

Compound 3, distribution coefficient: 2.7
The estimate for compound 3 lay 0.30 log units above the measured number; low and high end bracket the measured number.
By their numbers in this assay, from the lowest: compound 2; then compounds 1 and 3 (each within the scatter of the next).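

Chloro in place of hydrogen on an aromatic carbon, ortho to an isopropoxy group, gives a number 0.20 log units higher from compound 1 to compound 3 (within the scatter) in this assay and is the first single change in this set that can be read alone. At this position, the chloro group does not separate the two compounds in this assay. No measured evidence accounts for this result. The compounds shown leave open whether chloro elsewhere on this ring would give the same result. They also leave open whether a methoxy group, a nitrile or an amine at this position would give a step beyond the scatter.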